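Chloro in Place of Hydrogen on the Anilino Ring of Compound 1

A few compounds are considered here, and "the series" means these few. Any claim that something is new, unique, unknown or untested is made for them only; others in the source may bear on it.

Compound 1 `CC(C)n1cnc2c(Nc3ccccc3)nc(NCOCc3ccc(C(=O)Nc4ccccc4N)cc3)nc21` was examined in a functional assay on HepG2 cells (Homo sapiens) for antiproliferative activity, read by CCK-8 assay, with a stated time of 72 h, tested at 2 uM (a higher number here means a stronger effect of the compound at the concentration tested, a lower number a weaker effect), where compound 1 gives 6.58%. Among the three measured compounds this is the second highest number: compound 2 `CC(C)n1cnc2c(Nc3ccccc3)nc(NCOCc3ccc(/C=C/C(=O)Nc4ccccc4N)cc3)nc21` gives 1.46%, and compound 3 `Nc1ccccc1NC(=O)c1ccc(Cn2cnc3c(Nc4ccccc4)nc(Cl)nc32)cc1` gives 49.6%. Within the data shown here, the only single-place step recorded, a number 5.1 percentage points lower from compound 1 to compound 2 (within the scatter), lies within the scatter, and it concerns the carbamoyl side of the molecule rather than the anilino ring. Compound 4 `CC(C)n1cnc2c(Nc3cccc(Cl)c3)nc(NCOCc3ccc(C(=O)Nc4ccccc4N)cc3)nc21` differs from compound 1 by chloro in place of hydrogen on an aromatic carbon. Among the measured compounds shown here, no measured pair touches this position, so the data give neither a size nor a direction for the step in this assay. For the measured compounds named here, the one step that is known, at a different place, stayed within the scatter, and the entry of a single chlorine is expected to leave the read-out close to that of compound 1, with no step beyond the scatter. Compound 4 is therefore expected to give 8%, between 0% and 25%, an expected step of a number 1.4 percentage points higher from compound 1 to compound 4 (within the scatter).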

Compound 4, a percentage reported as inhibition, at one concentration (the size of the read-out at that concentration, not a potency): 1.48%
Compound 4: middle estimate off by 6.5 percentage points, on the high side, and the stated range covers the measured number.
By their numbers in this assay, from the lowest: compounds 2, 4 and 1 (each within the scatter of the next); then compound 3.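

Chloro in place of hydrogen on the anilino ring, meta to a large group, gives in this assay a first reading at this position: a number 5.1 percentage points lower from compound 1 to compound 4 (within the scatter), so this change produces no step beyond the scatter. Compound 1 gives only 6.58% in this assay, which leaves little room for a lower number, so the result speaks against a large gain from this chlorine at this place but says little about any loss. Nothing available accounts for the result or explains what the chlorine does here.

From the compounds shown here alone, whether an amine, a methoxy group or a carboxylic acid in this place would give a step beyond the scatter remains open. Also open, going by these compounds, is whether chloro on another carbon of this ring, or the same change on compound 3, would give a larger step.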